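This account rests on a few compounds, and the source may have more. Where it says the series, first, only, none or still open, it means among the compounds named here.

Of the compounds shown here, two built on one shared core have been measured in a functional assay on U-87MG ATCC cells for antiproliferative activity against U-87 MG (Homo sapiens), read by MTT assay, with a stated time of 48 h, tested at 100 uM; on this read-out lower numbers stand for a stronger effect and higher numbers for a weaker effect at the one concentration tested. Compound 1 `COc1ccc(-c2nc(C)c(C(=O)CSc3nc(-c4ccc(OC)c(OC)c4)c(C#N)c(=O)[nH]3)s2)cc1` gives 5.39% in this assay. Within the data shown here, compound 2 `COc1ccc(-c2nc(C)c(C(=O)CSc3nc(-c4ccccc4)c(C#N)c(=O)[nH]3)s2)cc1` gives 10.9% in this assay, and these two numbers sit within the usual scatter of each other, so the single step known so far, a number 5.5 percentage points higher from compound 1 to compound 2 (within the scatter), does not mark a real difference. Compound 3 `COc1ccc(-c2nc(C)c(C(=O)CSc3nc(-c4cccc(Cl)c4)c(C#N)c(=O)[nH]3)s2)cc1` has not yet been measured. It differs from compound 2 by chloro in place of hydrogen on an aromatic carbon. Among the measured compounds shown here, the one measured step concerns a different exchange on that same ring, so it gives only indirect guidance: it shows that altering this ring in one way left the read-out within the scatter. No step beyond the scatter is expected for a number 0.9 percentage points lower from compound 2 to compound 3 (within the scatter) either. Compound 3 is estimated to give 10%, with a range from 2% to 25%.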

Compound 3, a percentage reported as activity, at one concentration (the size of the read-out at that concentration, not a potency): 40.6%
Compound 3: middle estimate off by 30.6 percentage points, on the low side; the whole stated range lies below it.
By their numbers in this assay, from the lowest: compounds 1 and 2 (each within the scatter of the next); then compound 3.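

In this assay the ring is not indifferent to every change: chloro in place of hydrogen brings a number 29.7 percentage points higher from compound 2 to compound 3 (beyond the scatter) and so weakens the effect at the one concentration tested, whereas the exchange seen earlier stayed within the scatter. The 3-chlorophenyl group also compares poorly with the 3,4-dimethoxyphenyl group, with a number 35.2 percentage points higher from compound 1 to compound 3 (beyond the scatter) for that exchange, so a single chlorine on an aromatic carbon, meta to a large group, is enough to separate compound 3 from both earlier compounds. Nothing available gives a reason for this loss of effect.

Going by these compounds, it remains open whether the loss belongs to chlorine itself or would also appear with another group at this place, such as fluoro, methyl or an amine. The compounds shown also leave open whether chloro elsewhere on the same ring would give the same result.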